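Shortening an octyl chain: cytotoxicity expected to hold steady

The compounds below may be only part of what the source reports. "The series", "measured", "known", "first", "only" and "open" are said of these compounds alone.

Compound 3 `CCCCCCCCNc1cncc(C(=O)NCc2ccccc2)n1` was tested in an ADME assay on Vero cells (Chlorocebus sabaeus) for cytotoxicity, read by microscopy, with a stated time of 6 days; a higher number here means that more compound is tolerated, a lower number that less compound is tolerated. For compound 3 the result is a limit of the assay, > 100000 nM. Compound 1 `CCCCCCNc1cnc(C(=O)NCc2ccccc2)cn1` likewise stops at a limit, >= 100000 nM. Compound 2 `CCCCNc1cncc(C(=O)NCc2ccccc2)n1` gives a number, 100000 nM. Within the data shown here, the only measured step, a number no lower from compound 2 to compound 3 (the limit leaves the size open), lengthens the chain, and its size cannot be read because compound 3 sits at the limit of > 100000 nM in this assay, at which 1 of the 3 values shown sits. Compound 4 `CCCCCCCNc1cncc(C(=O)NCc2ccccc2)n1` differs from compound 3 by a shorter chain: hydrogen in place of methyl on a saturated chain carbon, seven bonds along the chain from a nitrogen on an aromatic ring. Compound 2 and compound 3 show the same number, one of them as a limit, so no movement beyond the scatter is expected from this change. The step is therefore estimated as a number no higher from compound 3 to compound 4 (the limit leaves the size open). Compound 4 is expected to give about 100000 nM, within 50000 nM to 200000 nM.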

Compound 4, minimum cytotoxic concentration: > 100000 nM
Compound 4 gave a limit, no number; the forecaster's own chance of this, stated with the estimate: 60%; the middle value sits exactly at the limit.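

Taking methyl off for hydrogen, seven bonds along the chain from a nitrogen on an aromatic ring, leaves the reading in this assay at a limit of the assay, so the step between compound 3 and compound 4 cannot be read: the limit of > 100000 nM in this assay, at which 2 of the 4 values shown sit.

The chain of compound 4 still gives only a direction against the shorter chain, a number no lower from compound 2 to compound 4 (the limit leaves the size open).

Going by these compounds, how much compound is tolerated beyond this limit stays open. So does whether a chain carrying an amine or a carboxylic acid would stop at the same limit.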